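Bromophenyl in Place of Methoxyphenyl on the Arylidene Arm

A few compounds are considered here, and "the series" means these few. Any claim that something is new, unique, unknown or untested is made for them only; others in the source may bear on it.

The measured compounds:
- compound 1 `O=C1N=C(N2CCC[C@H]2C(=O)Nc2ccc3ncnc(Nc4cccc(Cl)c4)c3c2)S/C1=C/c1ccc(Br)s1` gives > 50000 nM in a functional assay on A549 cells (Homo sapiens) for antiproliferative activity, read by MTT assay; on this read-out higher numbers stand for weaker inhibition and lower numbers for stronger inhibition; this is a limit of the assay, not a number.
- compound 2 `COc1ccc(/C=C2/SC(N3CCC[C@H]3C(=O)Nc3ccc4ncnc(Nc5cccc(Cl)c5)c4c3)=NC2=O)cc1` gives 31700 nM in this assay.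
- compound 3 `O=C1N=C(N2CCC[C@H]2C(=O)Nc2ccc3ncnc(Nc4cccc(Cl)c4)c3c2)S/C1=C/c1ccc(-c2ccccc2)cc1` gives 24200 nM in this assay.

Compound 2 holds the highest of the two numbers shown; its nearest neighbour is compound 3, with a 1.3-fold lower number from compound 2 to compound 3 (0.12 log units; within the scatter), a gap that is within the scatter. Compound 1 sits at the limit (the limit of > 50000 nM in this assay, at which 1 of the 3 values shown sits), and the step of an at least 1.5-fold lower number from compound 1 to compound 2 (0.19 log units; that floor lies within the scatter) has a floor that lies within the scatter, while an at least 2.0-fold lower number from compound 1 to compound 3 (0.31 log units; beyond the scatter) is at least modest.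

Compound 4 `O=C1N=C(N2CCC[C@H]2C(=O)Nc2ccc3ncnc(Nc4cccc(Cl)c4)c3c2)S/C1=C/c1ccccc1Br` is not yet measured. Its change from compound 2 is 2-bromophenyl in place of 4-methoxyphenyl on a double-bonded chain carbon bound to a double-bonded ring carbon. The closest guide is compound 1, where a bromine-bearing aromatic group on the same chain carbon gave only a limit, and the step from it to compound 2 was small. The change from methoxy to phenyl between compound 2 and compound 3 also moved little. Compound 4 is therefore expected to stay in the same weak range or drift somewhat higher, with an estimated step of a 1.3-fold higher number from compound 2 to compound 4 (0.10 log units; within the scatter). Compound 4 is estimated at 40000 nM, with a range from 15000 nM to 100000 nM.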

Compound 4, half-maximal inhibitory concentration: > 50000 nM
Compound 4: no number, only a limit; the forecaster's own chance of this, stated with the estimate: 40%; middle value at least 1.2-fold (0.09 log units) from the limit.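

Compound 1 and compound 4, the two compounds with a bromine-bearing aromatic group on this chain carbon, both stand at a limit of the assay rather than at a number: the limit of > 50000 nM in this assay, at which 2 of the 4 values shown sit. Measured against 4-phenylphenyl, 2-bromophenyl gives an at least 2.0-fold higher number from compound 3 to compound 4 (0.31 log units; beyond the scatter), so these two groups can be told apart at this place, while against 4-methoxyphenyl it gives an at least 1.5-fold higher number from compound 2 to compound 4 (0.19 log units; that floor lies within the scatter), so those two cannot. The step between compound 1 and compound 4 cannot be read, as both are limits.

The compounds shown leave open whether 4-bromophenyl would behave like 2-bromophenyl, so the bromine and its place on the ring cannot be separated. They also leave open whether a phenyl carrying an amine or a carboxylic acid on this chain carbon would give a clearly lower number.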